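Amino on the anilino ring: expected step in cytotoxicity

The compounds below may be only part of what the source reports. "The series", "measured", "known", "first", "only" and "open" are said of these compounds alone.

Compound 1, `Fc1cccc(-c2nc(Nc3ccccc3)c3cc(F)ccc3n2)c1`, is tested in a functional assay on HT29-AK cells (Homo sapiens) for cytotoxicity, read by MTT assay, with a stated time of 48 h (a higher number here means a weaker inhibitor, a lower number a stronger inhibitor), where compound 1 gives 48300 nM; its place among the two plain numbers is set by a 1.2-fold lower number from compound 1 to compound 3 (0.08 log units; within the scatter). Compound 3, `Fc1cccc(-c2nc(Nc3ccc(Cl)cc3)c3cc(F)ccc3n2)c1`, gives 40300 nM in this assay. Compound 2, `Fc1ccc(Nc2nc(-c3cccc(F)c3)nc3ccc(F)cc23)cc1`, gives > 50000 nM in this assay, which is a limit of the assay and not a number, as the limit of > 50000 nM in this assay, at which 1 of the 3 values shown sits, shows. Compound 4, `Nc1ccc(Nc2nc(-c3cccc(F)c3)nc3ccc(F)cc23)cc1`, differs from compound 1 by amino in place of hydrogen on an aromatic carbon. The two measured changes at the same place, an at least 1.0-fold higher number from compound 1 to compound 2 (0.01 log units; that floor lies within the scatter) and a 1.2-fold lower number from compound 1 to compound 3 (0.08 log units; within the scatter), both stay within the scatter, so no step beyond the scatter is expected in this assay for compound 4. Compound 4 is therefore expected at 45000 nM, between 20000 nM and 100000 nM. The expected step is a 1.1-fold lower number from compound 1 to compound 4 (0.03 log units; within the scatter).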

Compound 4, half-maximal inhibitory concentration: > 50000 nM
Compound 4: only a limit was reported; the forecaster's own chance of this, stated with the estimate: 35%; at least 1.1-fold (0.04 log units) between middle value and limit.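

Compound 4 joins compound 2 in reaching only a limit of this assay, not a number: the limit of > 50000 nM in this assay, at which 2 of the 4 values shown sit. Amino in place of hydrogen gives an at least 1.0-fold higher number from compound 1 to compound 4 (0.01 log units; that floor lies within the scatter), and amino in place of chloro gives an at least 1.2-fold higher number from compound 3 to compound 4 (0.09 log units; that floor lies within the scatter), so neither comparison shows a change at this position beyond the scatter. Compound 2 and compound 4 both stand as limits, and the step between them cannot be read.

On these data alone, whether a methoxy group or a carboxylic acid at this position would give a clearly lower number than compound 1 in this assay stays open.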